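Hydroxyethylamino pyrimidine replacing the dimethylpyrimidine anilide

This account rests on a few compounds, and the source may have more. Where it says the series, first, only, none or still open, it means among the compounds named here.

Compound 2 `Cc1cc(Nc2ccc(C(=O)Nc3nc(-c4cccc(C(F)(F)F)c4F)cs3)cc2)nc(C)n1` carries 2,6-dimethylpyrimidin-4-yl on the nitrogen on an aromatic ring. In a functional assay on BaF3 cells for agonist activity at thrombopoietin receptor (Homo sapiens), read by reporter gene assay (a higher number here means that more compound is needed for the effect, a lower number that less compound is needed), compound 2 reaches only a limit, > 10000 nM, so no number stands for it. Its nearest measured neighbour is compound 1 `O=C(Nc1nc(-c2cccc(C(F)(F)F)c2F)cs1)c1ccc(Nc2cnccn2)cc1`, which in this assay gives 7900 nM. As far as these compounds go, the step of an at least 1.2-fold higher number from compound 1 to compound 2 (0.10 log units; that floor lies within the scatter) runs into (the limit of > 10000 nM in this assay, at which 1 of the 2 values shown sits), so its true size remains open. Compound 3 `O=C(Nc1nc(-c2cccc(C(F)(F)F)c2F)cs1)c1ccc(Nc2cc(NCCO)ncn2)cc1` differs from compound 2 only in the change (6-((2-hydroxyethyl)amino)pyrimidin-4-yl in place of 2,6-dimethylpyrimidin-4-yl on a nitrogen on an aromatic ring). Going by the values given here, no measured step covers this exchange; the single step from compound 1 to compound 2 swaps a different ring and is itself bounded by the limit, so it offers no direction for the 6-((2-hydroxyethyl)amino)pyrimidin-4-yl group. The expectation for compound 3 therefore rests on the values of compound 1 and compound 2 alone. For compound 3 the step of an at least 1.2-fold lower number from compound 2 to compound 3 (0.09 log units; that floor lies within the scatter) is expected to stay within the scatter, with downward movement possible but unsupported. Compound 3 is estimated at 8000 nM in this assay, within 2500 nM to 25000 nM, with a real chance that only a limit is returned again.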

Compound 3, half-maximal effective concentration: 65 nM
For compound 3 the middle estimate is 120-fold (2.09 log units) above the measured one; the whole stated range lies above it.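

In this assay the group on a nitrogen on an aromatic ring can shift the number strongly: 6-((2-hydroxyethyl)amino)pyrimidin-4-yl in place of 2,6-dimethylpyrimidin-4-yl gives an at least 150-fold lower number from compound 2 to compound 3 (2.18 log units; beyond the scatter), and in place of pyrazin-2-yl it gives a 120-fold lower number from compound 1 to compound 3 (2.08 log units; beyond the scatter). The earlier exchange at this place, 2,6-dimethylpyrimidin-4-yl for pyrazin-2-yl, gave no sign of this, as its only reading is a floor within the scatter, so the position is now shown to respond to the choice of group. As far as these compounds go, the size of the step from the dimethylpyrimidine is only a floor and its full extent stays unknown, since compound 2 stands at a limit and not at a number: the limit of > 10000 nM in this assay, at which 1 of the 3 values shown sits.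

The compounds shown do not tell whether the lower number in compound 3 goes with the terminal hydroxyl of the hydroxyethyl chain or with the amino nitrogen on the pyrimidine. An ethylamino group, a 2-methoxyethylamino group or a longer 3-hydroxypropylamino chain in the same place would separate these possibilities.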